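Tetrabromobenzotriazole alcohols: fluoro for bromo on the aryl ring

The source may report more compounds than this note shows. Statements on the series, on what has been measured and on what is new or still open speak of the compounds shown alone.

Measured so far:
compound 1 `OC(CCn1nc2c(Br)c(Br)c(Br)c(Br)c2n1)c1ccc(Br)cc1`: 15%
compound 2 `CC(O)CCn1nc2c(Br)c(Br)c(Br)c(Br)c2n1`: 76%
compound 3 `OC(CCn1nc2c(Br)c(Br)c(Br)c(Br)c2n1)c1cccc(Br)c1`: 11%

In a functional assay on MCF7 cells (Homo sapiens) for antiproliferative activity, read by MTT assay, with a stated time of 48 h, tested at 50 uM (on this read-out higher numbers stand for a weaker effect at the one concentration tested and lower numbers for a stronger effect), compound 1 gives 15%, the second highest of the three numbers. Its nearest neighbour is compound 3, and a number 4 percentage points lower from compound 1 to compound 3 (within the scatter), so the two cannot be told apart. Compound 2 is furthest off: a number 61 percentage points higher from compound 1 to compound 2 (beyond the scatter), and the reverse comparison, a number 65 percentage points lower from compound 2 to compound 3 (beyond the scatter), is of the same kind. Among the measured compounds shown here, both large steps concern the exchange of methyl for a bromophenyl group; the only change that stays on the aryl ring, from compound 1 to compound 3, stays within the scatter.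

Compound 4 `OC(CCn1nc2c(Br)c(Br)c(Br)c(Br)c2n1)c1ccc(F)cc1` differs from compound 1 by fluoro in place of bromo on an aromatic carbon. For the measured compounds named here, no measured step exchanges one halogen for another on the aryl ring, so the nearest guide is the small step from compound 1 to compound 3, which moved bromo around the same ring. The expectation is therefore a step of a number 5 percentage points higher from compound 1 to compound 4 (within the scatter), with no change beyond the scatter. Compound 4 is estimated at 20%, in a range from 6% to 45%.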

Compound 4, a percentage reported as activity, at one concentration (the size of the read-out at that concentration, not a potency): 7%
Estimate against measurement, compound 4: 13 percentage points above; the measured number falls inside the stated range.
By their numbers in this assay, from the lowest: compounds 4, 3 and 1 (each within the scatter of the next); then compound 2.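

A step of a number 8 percentage points lower from compound 1 to compound 4 (within the scatter) shows that in this assay 4-fluorophenyl can take over from 4-bromophenyl with no change beyond the scatter. A step of a number 4 percentage points lower from compound 3 to compound 4 (within the scatter) also leaves 4-fluorophenyl indistinguishable from 3-bromophenyl, while a step of a number 69 percentage points lower from compound 2 to compound 4 (beyond the scatter) shows that the large gap from the methyl compound does not depend on bromo being on the aryl ring. No evidence is available to explain the halogen exchange.

Whether the aryl ring needs a halogen at all remains open, since plain phenyl is not among the compounds shown. Also open, on these data alone, is how an amine, a carboxylic acid or methoxy would read at this position, and whether a longer chain would be tolerated.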